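The compounds below may be only part of what the source reports. "The series", "measured", "known", "first", "only" and "open" are said of these compounds alone.

Measured compounds:
- compound 1, `C=CC(=O)N1C(=O)CC(c2ccc(C(=O)OC)cc2)Sc2ccccc21`: 79600 nM
- compound 2, `C=CC(=O)N1C(=O)CC(c2ccccc2Cl)Sc2ccccc21`: 80300 nM
- compound 3, `C=CC(=O)N1C(=O)CC(c2ccc(-c3ccccc3)cc2)Sc2ccccc21`: 97500 nM

In a functional assay on MOLT-4 cells (Homo sapiens) for cytotoxicity, read by CCK-8 assay, with a stated time of 24 h (on this read-out lower numbers stand for stronger inhibition and higher numbers for weaker inhibition), compound 3 gives the highest of the three numbers, yet it sits within the scatter of both its neighbours: compound 2 shows 80300 nM and compound 1 shows 79600 nM, so no order among the three can be claimed. Within the data shown here, the one step that can be followed within this set is the exchange of a single group on the shared core, which changes the read-out by a 1.2-fold higher number from compound 1 to compound 3 (0.09 log units; within the scatter), within the scatter.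

Compound 4, `C=CC(=O)N1C(=O)CC(c2ccc(C#N)cc2)Sc2ccccc21`, differs from compound 3 by cyano in place of phenyl on an aromatic carbon. Among the measured compounds shown here, no measured step exchanges phenyl for cyano, so the only guidance is indirect: the step from compound 1 to compound 3 shows that swapping one group at this aromatic carbon left this assay essentially unchanged, and the three measured values themselves spread over less than the scatter. Compound 4 is therefore expected to remain in the same region, with a step of a 1.1-fold lower number from compound 3 to compound 4 (0.06 log units; within the scatter) that is not expected to exceed the scatter. The estimate for compound 4 is 85000 nM, with a range from 40000 nM to 180000 nM.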

Compound 4, half-maximal inhibitory concentration: 88700 nM
Estimate against measurement, compound 4: 1.0-fold (0.02 log units) below, and the stated range covers the measured number.
By their numbers in this assay, from the lowest: compounds 1, 2, 4 and 3 (each within the scatter of the next).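

The exchange of phenyl for cyano on this aromatic carbon, para to a large group, removes a whole aromatic ring and brings in a triple bond and a hydrogen-bond acceptor, yet in this assay it gives a 1.1-fold lower number from compound 3 to compound 4 (0.04 log units; within the scatter) and nothing more. Among these compounds, the exchange of methoxycarbonyl for cyano on the same carbon gives a 1.1-fold higher number from compound 1 to compound 4 (0.05 log units; within the scatter) as well, so phenyl, methoxycarbonyl and cyano now all stand within the scatter of one another at this carbon, which the single earlier step could not show. The wider exchange of 2-chlorophenyl for 4-cyanophenyl on a saturated ring carbon, with a 1.1-fold higher number from compound 2 to compound 4 (0.04 log units; within the scatter) as its step, also leaves the read-out unresolved, and no supporting evidence bears on why these exchanges make so little difference.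

On these data alone, whether an amine or a carboxylic acid on this aromatic carbon would shift the number beyond the scatter stays open. The compounds shown also leave open whether any exchange on the shared core itself, rather than on its aryl group, would separate compounds in this assay at all.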